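Three measured compounds and an unmeasured 3-ethoxyphenyl analogue

A few compounds are considered here, and "the series" means these few. Any claim that something is new, unique, unknown or untested is made for them only; others in the source may bear on it.

In an assay on HEK293 cells for displacement of a labelled ligand from Melanocortin receptor 4 (Homo sapiens) (a higher number here means a weaker inhibitor, a lower number a stronger inhibitor), three compounds have been measured:

compound 1, `COc1ccc(CC(C)C(=O)N2CCN(c3ccc(C(F)(F)F)cc3[C@@H](N)CC(C)C)CC2)cc1`: 120 nM
compound 2, `CC(C)C[C@H](N)c1ccccc1N1CCN(C(=O)[C@H](C)Cc2ccc(Cl)cc2F)CC1`: 67 nM
compound 3, `CC(C)C[C@H](N)c1ccccc1N1CCN(C(=O)[C@H](C)Cc2ccc(Cl)cc2Cl)CC1`: 16 nM

Compound 1 gives the highest of the three numbers. Its gap to compound 2 lies within the scatter, so the two cannot be placed in order; its gap to compound 3 lies beyond the scatter. For the measured compounds named here, the one step that can be read between measured compounds is a 4.2-fold lower number from compound 2 to compound 3 (0.62 log units; beyond the scatter), a change on the aromatic ring of the benzyl arm in the core shared by compounds 2 and 3.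

Compound 4, `CCOc1cccc(CC(C)C(=O)N2CCN(c3ccc(C(F)(F)F)cc3[C@@H](N)CC(C)C)CC2)c1`, differs from compound 1 by 3-ethoxyphenyl in place of 4-methoxyphenyl on a saturated chain carbon, two bonds along the chain from a carbonyl carbon. Going by the values given here, this change is of a different kind from the one in the measured step: it moves and lengthens the alkoxy substituent rather than swapping one halogen for another, and it sits on the trifluoromethyl-bearing core of compound 1, not on the core of compounds 2 and 3. Among the compounds with values here, no measured pair therefore bears directly on it. The measured step shows that a single change on this aromatic ring can move the number by a modest amount, so a shift of that order in either direction is plausible, but nothing points to a direction. Compound 4 is expected to give 110 nM, within 40 nM to 320 nM, which means an expected step of a 1.1-fold lower number from compound 1 to compound 4 (0.04 log units; within the scatter) that is not beyond the scatter.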

Compound 4, inhibition constant: 2200 nM
Beside the measured number, compound 4's estimate is 20-fold (1.30 log units) below it; measured number above the stated range.
By their numbers in this assay, from the lowest: compound 3; then compounds 2 and 1 (each within the scatter of the next); then compound 4.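

In this assay, 3-ethoxyphenyl in place of 4-methoxyphenyl, on a saturated chain carbon, two bonds along the chain from a carbonyl carbon, gives an 18-fold higher number from compound 1 to compound 4 (1.26 log units; beyond the scatter), a large step beyond the scatter. The earlier compounds shown here showed only a halogen exchange on this aromatic ring, on a different core, and a modest step; this result shows that on the core of compound 1 the number at this position can rise sharply, even though the entering group differs from the leaving one by a single heavy atom, a carbon, and has the same counts of donors and acceptors. No evidence in hand accounts for the size of this step.

The step joins two alterations, the place of the alkoxy group on the ring and the length of its chain, and the compounds shown do not tell which of them carries it; 3-methoxyphenyl and 4-ethoxyphenyl on the same chain carbon would separate the two. On these data alone, whether 3-ethoxyphenyl would have a similar effect on the core shared by compounds 2 and 3 also remains open.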